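Cyano to (trifluoromethyl)sulfanyl: compound 3 to compound 4

The source may hold more compounds than are shown below. What is called first, only, known or untested is meant among the compounds shown, and "the series" means these compounds.

In a physicochemical assay for solubility, using the shake flask method, in simulated intestinal fluid, measured as kinetic solubility, with a stated time of 2 h, at 25 degrees C, at pH 6.5 (on this read-out lower numbers stand for lower solubility and higher numbers for higher solubility), compound 1 (`Cc1noc(-c2nc(C)c3c(c2N)C(=O)N(Cc2ccc(Oc4ccc(F)cc4)cc2)C3=O)n1`) gives 23800 nM. Compound 2 (`Cc1noc(-c2nc(C)c3c(c2N)C(=O)N(Cc2ccc(OC(F)F)cc2)C3=O)n1`) gives < 5000 nM, which is a limit and not a number. Compound 3 (`Cc1noc(-c2nc(C)c3c(c2N)C(=O)N(Cc2ccc(C#N)cc2)C3=O)n1`) gives < 5000 nM, likewise a limit. Compound 3 therefore stands only at the limit of < 5000 nM in this assay, at which 2 of the 3 values shown sit.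

Compound 4 (`Cc1noc(-c2nc(C)c3c(c2N)C(=O)N(Cc2ccc(SC(F)(F)F)cc2)C3=O)n1`) carries (trifluoromethyl)sulfanyl in place of cyano on an aromatic carbon, para to a large group: (trifluoromethyl)sulfanyl in place of cyano on an aromatic carbon.

For the measured compounds named here, three measured steps bear on this change. Losing the ring-bearing 4-fluorophenoxy group gives an at least 4.7-fold lower number from compound 1 to compound 3 (0.67 log units; beyond the scatter), and also an at least 4.7-fold lower number from compound 1 to compound 2 (0.67 log units; beyond the scatter). Between the two ring-free groups there is a step that the two limits leave unreadable from compound 2 to compound 3. The entering group has no ring either, so compound 4 is expected to stay close to compound 3, with no step beyond the scatter in either direction. Going by the values given here, this expectation rests on compound 1 being the only ring-bearing example, at 23800 nM. The expected step is a step that the limit leaves unreadable from compound 3 to compound 4, a rough estimate taken against a limit. For compound 4 the estimated value is 4000 nM. The expected range for compound 4 runs from 1500 nM to 15000 nM, and a report as a limit alone is likely.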

Compound 4, solubility: < 5000 nM
Compound 4 ended at the assay's limit; the forecaster's own chance of this, stated with the estimate: 70%; the middle value does not contradict the limit.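

In this assay, a third ring-free group on this aromatic carbon, para to a large group, ends in the same place as the other two: the limit of < 5000 nM in this assay, at which 3 of the 4 values shown sit.

Putting (trifluoromethyl)sulfanyl in place of 4-fluorophenoxy gives an at least 4.7-fold lower number from compound 1 to compound 4 (0.67 log units; beyond the scatter), so the drop seen with difluoromethoxy and cyano now holds for a third replacement, and compound 1 remains the only compound shown with a value that is not a limit. The steps among compound 2, compound 3 and compound 4 cannot be read, as each joins two limits.

For the compounds shown here, compound 1 is the single ring-bearing example, so it remains open whether its higher value belongs to the ring or to the 4-fluorophenoxy group as a whole. An amine or a carboxylic acid at this position, or a plain phenoxy group, would test how far the read-out can move away from the limit.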